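This account rests on a few compounds, and the source may have more. Where it says the series, first, only, none or still open, it means among the compounds named here.

Compound 1 `Cn1c(=O)c(S(=O)(=O)c2ccc(F)cc2F)cc2cnc(Nc3ccc4cc[nH]c4c3)nc21` is tested in a functional assay on K562 cells (Homo sapiens) for inhibition, read by trypan blue exclusion, with a stated time of 72 h (on this read-out higher numbers stand for weaker inhibition and lower numbers for stronger inhibition), where compound 1 gives 5000 nM. On this number compound 1 stands level with compound 3 `Cn1c(=O)c(S(=O)(=O)c2ccc(F)cc2)cc2cnc(Nc3ccc4occc4c3)nc21`, which in this assay gives 5000 nM; the two share the highest value of the three at the digits shown, and their gap lies within the scatter. Compound 2 `Cn1c(=O)c(S(=O)(=O)c2ccc(F)cc2[N+](=O)[O-])cc2cnc(Nc3ccc4[nH]ccc4c3)nc21` sits apart: in this assay compound 2 gives 900 nM, a lower number than compound 1 by a margin beyond the scatter. Compound 4 `Cn1c(=O)c(S(=O)(=O)c2ccc(F)cc2F)cc2cnc(Nc3ccc4[nH]c(C(=O)O)cc4c3)nc21` differs from compound 1 in one place (2-carboxy-1H-indol-5-yl in place of 1H-indol-6-yl on a nitrogen on an aromatic ring). Within the data shown here, no measured pair isolates this change, so its direction is open; only a modest movement in this assay, if any beyond the scatter, is expected. For compound 4 the estimate in this assay is 4000 nM, between 1000 nM and 15000 nM. The expected step is a 1.3-fold lower number from compound 1 to compound 4 (0.10 log units; within the scatter).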

Compound 4, half-maximal inhibitory concentration: 10000 nM
Compound 4: the middle estimate sits 2.5-fold (0.40 log units) below what was measured; the range from low to high includes it.
By their numbers in this assay, from the lowest: compound 2; then compounds 1, 3 and 4 (each within the scatter of the next).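

In this assay, 2-carboxy-1H-indol-5-yl in place of 1H-indol-6-yl on a nitrogen on an aromatic ring gives a 2.0-fold higher number from compound 1 to compound 4 (0.30 log units; within the scatter), the first step read at this place. The added carboxy group and the changed indole attachment together therefore produce no movement beyond the scatter, and this pair shows no gain in inhibition. Nothing available here accounts for the step.

The pair leaves open how the attachment and the carboxy group each contribute on their own. It also leaves open whether a methyl ester or a primary amide in place of the carboxylic acid would stand apart from compound 4.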